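The compounds below may be only part of what the source reports. "The series", "measured", "known", "first", "only" and "open" are said of these compounds alone.

Compound 1 `COc1cc(O)c(C(=O)/C=C/c2cccc(O)c2)c(OC)c1` is the weakest of the three chalcones measured so far in a functional assay on B16-F10 cells (Mus musculus) for inhibition, with a stated time of 4 days (a higher number here means a weaker inhibitor, a lower number a stronger inhibitor), where compound 1 gives 9900 nM. Compound 2 `CCc1ccccc1/C=C/C(=O)c1c(O)cc(OC)cc1OC` gives 2500 nM in this assay, and compound 3 `COc1cc(O)c(C(=O)/C=C/c2ccccc2C(C)C)c(OC)c1` gives 2700 nM; each of these two sits well below compound 1, a gap beyond the usual scatter, whereas the two of them differ by only a 1.1-fold higher number from compound 2 to compound 3 (0.03 log units; within the scatter).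

Compound 4 `COc1cc(O)c(C(=O)/C=C/c2ccc(O)cc2)c(OC)c1` is the positional isomer of compound 1 obtained by the change (4-hydroxyphenyl in place of 3-hydroxyphenyl on a double-bonded chain carbon bound to a double-bonded chain carbon). Within the data shown here, no measured pair speaks to this change: the one step that is known, from compound 2 to compound 3, concerns an alkyl group on the same ring and was within the scatter, and compounds 2 and 3 carry their substituent at a different place from the hydroxyl of compound 1, so their distance from compound 1 cannot be read as a guide to a hydroxyl moved on the ring. The hydrogen-bond donor and acceptor count is unchanged. Compound 4 is therefore expected to stay close to compound 1, with a step of a 1.1-fold lower number from compound 1 to compound 4 (0.04 log units; within the scatter) that lies within the scatter, and its estimated value in this assay is 9000 nM, with a likely range from 3000 nM to 30000 nM.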

Compound 4, half-maximal inhibitory concentration: 6900 nM
The estimate for compound 4 lay 1.3-fold (0.12 log units) above the measured number; the measured number falls inside the stated range.
By their numbers in this assay, from the lowest: compounds 2 and 3 (each within the scatter of the next); then compounds 4 and 1 (each within the scatter of the next).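

In this assay, the exchange of 3-hydroxyphenyl for 4-hydroxyphenyl on a double-bonded chain carbon bound to a double-bonded chain carbon gives a 1.4-fold lower number from compound 1 to compound 4 (0.16 log units; within the scatter), with the rest of the core of compound 1 unchanged. Among the steps shown, this is the only one that moves a hydroxyl rather than extending an alkyl group, and it shows that for this pair the two hydroxyphenyl isomers cannot be told apart in this read-out, so the hydroxyl can be carried in either of these two forms without a change beyond the scatter. Nothing measured here offers an explanation for this result.

The compounds shown leave open whether the hydroxyl itself contributes at all, since the comparison of 3-hydroxyphenyl and 4-hydroxyphenyl says nothing about how a plain phenyl would read at this place. They also leave open how a phenyl carrying an amine, a carboxylic acid or a longer chain ending in either group would compare with compound 1 and compound 4 at this same place.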